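A few compounds are considered here, and "the series" means these few. Any claim that something is new, unique, unknown or untested is made for them only; others in the source may bear on it.

Among the measured compounds shown here, compound 1 `O=C(CSc1nnnn1-c1ccccc1)N/N=c1/scc(-c2ccc(Br)cc2)n1-c1ccccc1` is one of two compounds so far measured in a functional assay on C6 cells (Rattus norvegicus) for cytotoxicity, read by MTT assay, with a stated time of 24 h, tested at 50 ug/mL; on this read-out lower numbers stand for a stronger effect and higher numbers for a weaker effect at the one concentration tested. In this assay compound 1 gives 32%, the lower of the two numbers recorded. Compound 2 `Cc1ccc(-c2cs/c(=N/NC(=O)CSc3nnnn3C)n2-c2ccccc2)cc1` in this assay gives 44.3%, a number that sits above that of compound 1 by more than the usual scatter of repeated runs; the two compounds differ at more than one place, so the numbers are noted side by side without reading a single change into them.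

The next compound, compound 3 `O=C(CSc1nnnn1-c1ccccc1)N/N=c1/scc(-c2ccc(Cl)cc2)n1-c1ccccc1`, has not been measured. From compound 1 to compound 3 the structure differs in one place: chloro in place of bromo on an aromatic carbon. Everything else in the molecule stays as in compound 1.

For the measured compounds named here, no measured pair shows this exchange of halogen, so the expectation rests on compound 1 alone. In this assay the step of a number 4 percentage points higher from compound 1 to compound 3 (within the scatter) is expected to stay within the scatter, with no direction favoured. Compound 3 is therefore estimated at 36% in this assay, with a range from 24% to 50%, because compound 1 gives 32% and the change is a single halogen on one aromatic carbon.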

Compound 3, a percentage reported as activity, at one concentration (the size of the read-out at that concentration, not a potency): 60%
For compound 3 the middle estimate is 24 percentage points below the measured one; the whole stated range lies below it.
By their numbers in this assay, from the lowest: compound 1; then compound 2; then compound 3.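

In this assay the exchange of 4-bromophenyl for 4-chlorophenyl gives a number 28 percentage points higher from compound 1 to compound 3 (beyond the scatter), so the halogen on this aromatic carbon, para to a large group, is not interchangeable in this series: with bromo replaced by chloro, the read-out moves towards a weaker effect at the one concentration tested. The earlier compounds shown here could not show this, as they differ at more than one place and offered no single change to read; this pair shows that one heavy atom at this position can by itself shift the result beyond the scatter. No measurement at hand accounts for the step, which stands as an observation on a single pair.

On these data alone, it remains open how fluoro, a methoxy group, an amine or a carboxylic acid on this same aromatic carbon would read, and whether fluoro would extend the shift seen on going from bromo to chloro. Also open, as far as these compounds go, is whether the exchange gives a step of similar size on other compounds, and whether it would hold at other concentrations.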